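Phenyl for 1-Phenylethyl on the Amide Nitrogen

The source may report more compounds than this note shows. Statements on the series, on what has been measured and on what is new or still open speak of the compounds shown alone.

Three measured compounds share one core and differ only in what the amide-type nitrogen carries. In an assay on membranes from Sf9 cells for displacement of a labelled ligand from histamine H2 receptor (Homo sapiens), read by scintillation counting, with a stated time of 60 min (on this read-out higher numbers stand for weaker inhibition and lower numbers for stronger inhibition), compound 1 `Cc1nc(N)sc1CCCN/C(N)=N/C(=O)NCC(C)CCc1ccccc1` gives 63.1 nM. Compound 2 `Cc1nc(N)sc1CCCN/C(N)=N/C(=O)N[C@@H](C)c1ccccc1` gives 51.3 nM in this assay, the lowest of the three numbers; the number of compound 1 lies within the scatter of repeated measurements, so those two compounds cannot be ranked against each other. Compound 3 `Cc1nc(N)sc1CCCN/C(N)=N/C(=S)N[C@H](C)c1ccccc1` gives 115 nM in this assay, a number beyond the scatter from compound 2; compound 3 differs from compound 2 in more than one place, so what its number shows cannot be tied to any single change.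

Compound 4 `Cc1nc(N)sc1CCCN/C(N)=N/C(=O)Nc1ccccc1` has not yet been measured. It differs from compound 2 in one place: phenyl in place of 1-phenylethyl on an amide-type nitrogen. Within the data shown here, no measured pair shows a change of this kind, so there is no direct guide to the size or direction of the step. The expectation is that the step from compound 2 to compound 4 in this assay is a 1.7-fold higher number from compound 2 to compound 4 (0.22 log units; within the scatter), a small move toward a higher number, not clearly beyond the scatter. Compound 4 is therefore estimated to give 85 nM in this assay, with a range from 30 nM to 250 nM.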

Compound 4, inhibition constant: 3160 nM
Beside the measured number, compound 4's estimate is 37-fold (1.57 log units) below it; measured number above the stated range.
By their numbers in this assay, from the lowest: compounds 2, 1 and 3 (each within the scatter of the next, the first and the last beyond it); then compound 4.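

In this assay, among these compounds, the exchange of 1-phenylethyl for phenyl on the amide-type nitrogen gives a 62-fold higher number from compound 2 to compound 4 (1.79 log units; beyond the scatter) and is the first step here that can be tied to a single change, showing that this position is far from indifferent to what it carries. By count the change looks small: 8 heavy atoms leave and 6 enter, both groups hold one six-membered aromatic ring of carbon only, neither has hydrogen-bond donors or acceptors, neither has a net charge, and the one defined stereocentre disappears. Nothing available explains why so modest a change in these counts goes with so large a step.

The change removes carbon atoms and the stereocentre together, so the compounds shown cannot say which of the two matters, or whether the ring must keep some distance from the nitrogen. A benzyl group on this nitrogen would have no stereocentre yet would keep a carbon link to the ring, and its number would help to separate these possibilities.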